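Swapping ethyl for ethoxy on a quinoline carboxylic acid

The compounds below may be only part of what the source reports. "The series", "measured", "known", "first", "only" and "open" are said of these compounds alone.

Compound 1 `CCc1cccc2cc(C(=O)O)cnc12` gives 75 mg/kg in a functional assay on the whole organism (strain Sprague-Dawley) for inhibition, with Rattus norvegicus as the target (a lower number here means that less compound is needed, a higher number that more compound is needed for the effect), the highest of the two numbers recorded. Compound 3 `CCc1cccc2cc(-c3nn[nH]n3)cnc12` gives 5 mg/kg there; the change from carboxy to a tetrazole ring brought a 15-fold lower number from compound 1 to compound 3 (1.18 log units; beyond the scatter). Compound 2 `Fc1cc(F)c2ncc(-c3nn[nH]n3)cc2c1` reached only a limit of the assay, > 50 mg/kg, so it yields no number. Compound 4 `CCOc1cccc2cc(C(=O)O)cnc12` differs from compound 1 by ethoxy in place of ethyl on an aromatic carbon. Among the compounds with values here, no measured pair shows this swap of a side group on the shared core, and the only measured step concerns the acid group, which compound 4 keeps. The expected step is therefore no change at the digits printed from compound 1 to compound 4 (within the scatter), none beyond the scatter. Compound 4 is estimated at 75 mg/kg, between 25 mg/kg and 250 mg/kg.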

Compound 4, minimum effective dose: > 50 mg/kg
Compound 4 was reported as a limit; the forecaster's own chance of this, stated with the estimate: 25%; the middle value is on the limit's open side.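

Compound 4 gives only a limit in this assay, > 50 mg/kg, so no step from compound 1 to compound 4 can be read: the limit of > 50 mg/kg in this assay, at which 2 of the 4 values shown sit.

Going by these compounds, whether ethoxy in place of ethyl changes the dose needed, and by how much, stays open.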